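Notes on the step from compound 2 to compound 3

A few compounds are considered here, and "the series" means these few. Any claim that something is new, unique, unknown or untested is made for them only; others in the source may bear on it.

Compound 1 `COc1cccc(Nc2nc3c(c(Oc4cccc(NC(=O)/C=C/C(C)C)c4)n2)CSCC3)c1`: > 50000 nM, a limit of the assay and not a number
Compound 2 `CC(C)=CC(=O)Nc1cccc(Oc2nc(Nc3cccc(C#N)c3)nc3c2CSCC3)c1`: 29200 nM

Both values come from a functional assay on HeLa cells (Homo sapiens) for antiproliferative activity, read by MTT assay, with a stated time of 72 h; a higher number here means a weaker inhibitor, a lower number a stronger inhibitor. Among the compounds with values here, compound 2 stands at 29200 nM, the only actual number so far, so there is no second number to rank it against.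

Compound 3 `CC(C)/C=C/C(=O)Nc1cccc(Oc2nc(Nc3cccc(C#N)c3)nc3c2CSCC3)c1` differs from compound 2 in one group: 3-methylbut-1-en-1-yl in place of 2-methylprop-1-en-1-yl on a carbonyl carbon. Put simply, 3-methylbut-1-en-1-yl stands in place of 2-methylprop-1-en-1-yl on a carbonyl carbon. Within the data shown here, no measured step gauges a change of this kind, so no shift beyond the scatter is expected in this assay, in either direction. The expected step of a 1.1-fold higher number from compound 2 to compound 3 (0.04 log units; within the scatter) therefore stays small, anchored on compound 2 at 29200 nM. Compound 3 is estimated at 32000 nM, with an expected range of 15000 nM to 50000 nM.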

Compound 3, half-maximal inhibitory concentration: 22800 nM
Compound 3: middle estimate off by 1.4-fold (0.15 log units), on the high side; the measured number falls inside the stated range.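

In this assay, the change on the carbonyl carbon gives a 1.3-fold lower number from compound 2 to compound 3 (0.11 log units; within the scatter), so 3-methylbut-1-en-1-yl and 2-methylprop-1-en-1-yl cannot be told apart at this position. Within the data shown here, compound 3 also provides the first step beyond the scatter, with cyano in place of methoxy on an aromatic carbon giving an at least 2.1-fold lower number from compound 1 to compound 3 (0.34 log units; beyond the scatter); the aromatic substituent therefore registers in this assay, while the acyl change does not. Compound 1 carries a limit and not a number, so this step has a lower bound only: the limit of > 50000 nM in this assay, at which 1 of the 3 values shown sits.

Still open, as far as these compounds go, is whether an amine or a carboxylic acid at the end of the group on the carbonyl carbon, or a longer chain there, would move the number beyond the scatter. Also open, from the compounds shown here alone, is how a fluorine or a trifluoromethyl group in place of cyano would compare with compound 3.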